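The compounds below may be only part of what the source reports. "The series", "measured", "known", "first", "only" and "open" are said of these compounds alone.

In a functional assay on HT-29 cells (Homo sapiens) for inhibition, read by sulforhodamine B assay (on this read-out higher numbers stand for weaker inhibition and lower numbers for stronger inhibition), compound 1, `COC(=O)CC/C(C)=C/Cc1c(OC)c(C)c2c(c1OCC#CCN1CCN(c3ccc(C#N)cc3)CC1)C(=O)OC2`, gives > 50000 nM, which is a limit of the assay and not a number. Compound 2, `COC(=O)CC/C(C)=C/Cc1c(OC)c(C)c2c(c1OCC#CCN1CCN(c3ccccc3F)CC1)C(=O)OC2`, gives > 50000 nM, also a limit. Compound 3, `COC(=O)CC/C(C)=C/Cc1c(OC)c(C)c2c(c1OCC#CCN1CCN(c3ccccc3OC)CC1)C(=O)OC2`, gives > 50000 nM, so it too stands only at a limit. It therefore has no measured number to start from, and the same holds for the other two compounds. The whole picture so far is the limit of > 50000 nM in this assay, at which 3 of the 3 values shown sit.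

The next structure, compound 4, `COC(=O)CC/C(C)=C/Cc1c(OC)c(C)c2c(c1OCC#CCN1CCN(C(=O)C3COc4ccccc4O3)CC1)C(=O)OC2`, changes the group on the piperazine-type ring: (2,3-dihydro-1,4-benzodioxin-2-yl)carbonyl in place of 2-methoxyphenyl on an amine nitrogen in a ring. In words, (2,3-dihydro-1,4-benzodioxin-2-yl)carbonyl comes in place of 2-methoxyphenyl on an amine nitrogen in a ring.

For the measured compounds named here, three measured steps bear on this change: a step that the two limits leave unreadable from compound 1 to compound 2, a step that the two limits leave unreadable from compound 1 to compound 3 and a step that the two limits leave unreadable from compound 2 to compound 3. None of them has a readable size, and none of them puts a carbonyl group on that nitrogen. The expectation in this assay thus rests on (the limit of > 50000 nM in this assay, at which 3 of the 3 values shown sit), and it is for no step beyond the scatter in either direction, with another limit the most likely report. The expected change is a number no higher from compound 3 to compound 4 (the limit leaves the size open). For compound 4 the estimate is 50000 nM, with an expected range from 20000 nM to 100000 nM.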

Compound 4, half-maximal inhibitory concentration: > 50000 nM
Compound 4 ended at the assay's limit (the forecaster's own chance of this, stated with the estimate: 75%); the middle value sits exactly at the limit.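

In this assay compound 4 gives > 50000 nM, which is a limit of the assay and not a number. Its steps from compound 1, compound 2 and compound 3 cannot be read, as each joins two limits. The compounds shown leave open whether any group on that amine nitrogen would give a measured number in this assay: the limit of > 50000 nM in this assay, at which 4 of the 4 values shown sit.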